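The source may hold more compounds than are shown below. What is called first, only, known or untested is meant among the compounds shown, and "the series" means these compounds.

Measured in a functional assay on HeLa cells (Homo sapiens) for antiproliferative activity, read by MTT assay, with a stated time of 72 h; on this read-out lower numbers stand for stronger inhibition and higher numbers for weaker inhibition:
- compound 1 `CCCCn1ccnc1-c1cc(OC)c(OC)c(OC)c1`: > 100000 nM (a limit)
- compound 2 `COc1cc(-c2nccn2S(=O)(=O)c2ccccc2)cc(OC)c1OC`: > 100000 nM (a limit)
- compound 3 `COc1cc(-c2nccn2-c2ccc3sccc3c2)cc(OC)c1OC`: 1400 nM

Compound 1 gives only a limit, > 100000 nM, and no number. It stands at the limit of > 100000 nM in this assay, at which 2 of the 3 values shown sit. Compound 2 also gives only a limit, so it does not show a number even though it carries an aromatic ring in its group on that nitrogen.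

The step to compound 4 `COc1cc(-c2nccn2-c2ccc(Br)cc2)cc(OC)c1OC` puts 4-bromophenyl in place of butyl on an aromatic nitrogen. Going by the values given here, no measured step isolates this change. The closest guide is compound 3, which has an aromatic ring directly on that nitrogen and gives 1400 nM. A large move toward stronger inhibition in this assay is therefore expected, though a result at the limit remains possible. The estimated step is an at least 20-fold lower number from compound 1 to compound 4 (1.30 log units; beyond the scatter). The estimate for compound 4 is 5000 nM, with an expected range of 800 nM to 40000 nM.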

Compound 4, half-maximal inhibitory concentration: 3300 nM
Beside the measured number, compound 4's estimate is 1.5-fold (0.18 log units) above it, within the range that was stated.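

In this assay, 4-bromophenyl in place of butyl on this aromatic nitrogen gives an at least 30-fold lower number from compound 1 to compound 4 (1.48 log units; beyond the scatter). Compound 1 gives > 100000 nM, a limit and not a number, so the size of this step is only a bound: the limit of > 100000 nM in this assay, at which 2 of the 4 values shown sit.

Together with compound 3, compound 4 shows that an aromatic ring set directly on this nitrogen gives a number, whereas compound 2, with its aromatic ring held through a sulfonyl group, gives only a limit.

As far as these compounds go, what the bromine itself contributes stays open, and a plain phenyl or a chlorine in place of the bromine would speak to that. Also open, from the compounds shown here alone, is whether a benzyl group, with a carbon link between the nitrogen and the ring, would give a number.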